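Swapping Nitro for Amino on a Benzyl Sulfone

This account rests on a few compounds, and the source may have more. Where it says the series, first, only, none or still open, it means among the compounds named here.

Compound 1 `COc1cc(/C=C/S(=O)(=O)Cc2ccc(OC)c([N+](=O)[O-])c2)cc(OC)c1` was tested in a functional assay on T47D cells (Homo sapiens) for cytotoxicity, read by MTT assay, with a stated time of 72 h; on this read-out higher numbers stand for weaker inhibition of growth and lower numbers for stronger inhibition of growth. In this assay compound 1 gives only a limit, > 30000 nM. Compound 2 `COc1ccc(CS(=O)(=O)CC(=O)Nc2ccccc2)cc1[N+](=O)[O-]` likewise gives only a limit, > 30000 nM. Compound 3 `COc1ccc(CS(=O)(=O)CC(=O)Nc2ccccc2)cc1N` differs from compound 2 by amino in place of nitro on an aromatic carbon; in this assay compound 3 also gives only a limit, > 30000 nM. The step that the two limits leave unreadable from compound 2 to compound 3 thus cannot be sized, since (the limit of > 30000 nM in this assay, at which 3 of the 3 values shown sit). The difference between the core of compound 1 and the core of compound 2 is not broken down here. Compound 4 `COc1cc(/C=C/S(=O)(=O)Cc2ccc(OC)c(N)c2)cc(OC)c1`, not yet measured, differs from compound 1 by amino in place of nitro on an aromatic carbon, the same change as from compound 2 to compound 3. Because the limit of > 30000 nM in this assay, at which 3 of the 3 values shown sit, holds for every measured compound, the step of a number no higher from compound 1 to compound 4 (the limit leaves the size open) is expected to be small. Compound 4 is therefore estimated at about 30000 nM, most likely again only a limit.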

Compound 4, concentration for 50% growth inhibition: 530 nM
Compound 4: the middle estimate sits 57-fold (1.75 log units) above what was measured; the measured number lies below the stated range.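

In this assay, amino in place of nitro on an aromatic carbon brings an at least 56-fold lower number from compound 1 to compound 4 (1.75 log units; beyond the scatter), a large step on the core of compound 1. The same change on the other core cannot be read, since compound 2 and compound 3 both stay at a limit of the assay, and so the values do not show whether the step carries over to that core: the limit of > 30000 nM in this assay, at which 3 of the 4 values shown sit. The change is thus sized on one core only, which neither proves nor rules out a similar effect on the other.

The compounds shown leave open whether amino itself is special, or whether another group, such as hydroxyl or a methylamino group, in place of the amino group of compound 4 would serve equally well. They also leave open why the two cores appear to differ.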